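The source may hold more compounds than are shown below. What is called first, only, known or untested is meant among the compounds shown, and "the series" means these compounds.

Compound 1 `CC(=O)OCCC(=O)O[C@H](CC=C(C)C)C1=CC(=O)c2c(O)ccc(O)c2C1=O` gives 15700 nM in a functional assay on DU-145 cells (Homo sapiens) for cytotoxicity, read by MTT assay; a higher number here means a weaker inhibitor, a lower number a stronger inhibitor. Compound 2 `CC[C@](C)(O)CC(=O)O[C@H](CC=C(C)C)C1=CC(=O)c2c(O)ccc(O)c2C1=O` gives 20500 nM in this assay; it has the higher of the two numbers, yet the step of a 1.3-fold higher number from compound 1 to compound 2 (0.12 log units; within the scatter) does not separate it from compound 1. Compound 3 `CC(C)=CC[C@@H](OC(=O)CC(C)(O)C(C)C)C1=CC(=O)c2c(O)ccc(O)c2C1=O` differs from compound 2 only by 1-hydroxy-1,2-dimethylpropyl in place of 1-hydroxy-1-methylpropyl on a saturated chain carbon bound to a carbonyl carbon. Within the data shown here, the one measured step that bears on it, a 1.3-fold higher number from compound 1 to compound 2 (0.12 log units; within the scatter), also altered the chain on the saturated chain carbon bound to a carbonyl carbon and stayed within the scatter, so the expected step of a 1.0-fold higher number from compound 2 to compound 3 (0.01 log units; within the scatter) is none beyond the scatter. Compound 3 is therefore expected to give about 21000 nM, between 10000 nM and 42000 nM.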

Compound 3, half-maximal inhibitory concentration: 16900 nM
Compound 3: the middle estimate sits 1.2-fold (0.09 log units) above what was measured; the range from low to high includes it.
By their numbers in this assay, from the lowest: compounds 1, 3 and 2 (each within the scatter of the next).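

At this position, 1-hydroxy-1,2-dimethylpropyl reads the same as 1-hydroxy-1-methylpropyl (a 1.2-fold lower number from compound 2 to compound 3 (0.08 log units; within the scatter)) and the same as acetoxymethyl (a 1.1-fold higher number from compound 1 to compound 3 (0.03 log units; within the scatter)). All three compounds therefore lie within the scatter of one another in this assay, so the extra carbon in this branched chain leaves no measurable mark here. No supporting evidence is available to explain this result.

On these data alone, it remains open whether an amine, a carboxylic acid or a much longer chain on this saturated chain carbon would move the number beyond the scatter.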